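The compounds below may be only part of what the source reports. "The series", "measured", "known", "first", "only" and "open" are said of these compounds alone.

Three compounds share one core and differ only in the groups hung on it. In a functional assay on MCF7 cells (Homo sapiens) for inhibition, read by MTT assay, with a stated time of 72 h (on this read-out higher numbers stand for weaker inhibition and lower numbers for stronger inhibition), compound 1, `O=C(Nc1ccc(Oc2ccnc3[nH]ccc23)cc1)c1cn(-c2ccc(C(F)(F)F)cc2Cl)c2ccccc2c1=O`, gives 3570 nM. Compound 2, `Cn1ccc2c(Oc3ccc(NC(=O)c4cn(-c5ccc(C(F)(F)F)cc5Cl)c5ccccc5c4=O)cc3F)ccnc21`, gives 190 nM in this assay. Compound 3, `O=C(Nc1ccc(Oc2ccnc3[nH]ccc23)c(F)c1)c1cn(-c2ccc(Br)cc2)c2ccccc2c1=O`, gives 650 nM in this assay. Among these three numbers compound 3 stands second highest: the number of compound 2 lies lower than that of compound 3 by more than the usual scatter, and the number of compound 1 lies higher than that of compound 3, again by more than the scatter.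

Compound 4, `O=C(Nc1ccc(Oc2ccnc3[nH]ccc23)c(F)c1)c1cn(-c2ccc(C(F)(F)F)cc2Cl)c2ccccc2c1=O`, has not yet been measured. It differs from compound 3 in one place: 2-chloro-4-(trifluoromethyl)phenyl in place of 4-bromophenyl on an aromatic nitrogen. Among the compounds with values here, no measured pair shows this swap on its own; compound 1 and compound 2 both carry the entering group but differ from compound 4 elsewhere, and their numbers fall on either side of compound 3. The step is expected to be modest, and from compound 3 to compound 4 the expected step is a 1.2-fold higher number from compound 3 to compound 4 (0.09 log units; within the scatter). Compound 4 is estimated at 800 nM, within a range from 250 nM to 2500 nM.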

Compound 4, half-maximal inhibitory concentration: 1120 nM
Compound 4: the middle estimate sits 1.4-fold (0.15 log units) below what was measured, within the range that was stated.
By their numbers in this assay, from the lowest: compound 2; then compounds 3 and 4 (each within the scatter of the next); then compound 1.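

In this assay, placing 2-chloro-4-(trifluoromethyl)phenyl on the aromatic nitrogen in place of 4-bromophenyl gives a 1.7-fold higher number from compound 3 to compound 4 (0.24 log units; within the scatter) and so, in this one pair, the two groups cannot be told apart, although they differ in heavy-atom count and substitution. Within the data shown here, compound 4 also links the earlier compounds through single changes that do register: hydrogen in place of methyl on an aromatic nitrogen gives a 5.9-fold higher number from compound 2 to compound 4 (0.77 log units; beyond the scatter) and fluoro in place of hydrogen on an aromatic carbon gives a 3.2-fold lower number from compound 1 to compound 4 (0.50 log units; beyond the scatter) in the same read-out. Nothing at hand explains the size of any of these steps.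

From the compounds shown here alone, whether the swap of the two phenyl groups would read the same with the methyl present or the fluoro absent remains open. So does the effect of an amine or a carboxylic acid on the phenyl ring at that nitrogen.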